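A few compounds are considered here, and "the series" means these few. Any claim that something is new, unique, unknown or untested is made for them only; others in the source may bear on it.

Going by the values given here, compound 2 `Cc1cc(-c2c(C)nn(-c3nc(-c4ccc(Cl)c(Cl)c4)c(SC(C)C)s3)c2C(=O)O)cc(C)n1` holds the lowest of the two numbers measured so far: in a functional assay on BJAB cells (Homo sapiens) for antiproliferative activity, with a stated time of 4 days (on this read-out lower numbers stand for an effect already at smaller amounts and higher numbers for an effect only at larger amounts of compound), compound 2 gives 580 nM. Among the compounds with values here, the only other measured compound is compound 1 `CCOc1ncccc1-c1c(C)nn(-c2nc(-c3ccc(Cl)c(Cl)c3)c(SC(C)C)s2)c1C(=O)O`, which in this assay gives 11000 nM; the two differ in a single place, and the step of a 19-fold lower number from compound 1 to compound 2 (1.28 log units; beyond the scatter) shows that exchanging the group on this aromatic carbon can move the read-out a long way. Compound 3 `Cc1cc(C#N)cc(-c2c(C)nn(-c3nc(-c4ccc(Cl)c(Cl)c4)c(SC(C)C)s3)c2C(=O)O)c1` changes the group on the same aromatic carbon once more: 3-cyano-5-methylphenyl in place of 2,6-dimethylpyridin-4-yl on an aromatic carbon. Within the data shown here, only one measured step bears on this change, a 19-fold lower number from compound 1 to compound 2 (1.28 log units; beyond the scatter), and it concerns a different pair of groups, so it mainly shows that large shifts are possible at this aromatic carbon, in either direction. Compound 3 is therefore expected to show a somewhat higher number, the expected step being a 2.6-fold higher number from compound 2 to compound 3 (0.41 log units; beyond the scatter). Compound 3 is estimated at 1500 nM in this assay, with a range from 400 nM to 6000 nM.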

Compound 3, half-maximal effective concentration: 4800 nM
Beside the measured number, compound 3's estimate is 3.2-fold (0.51 log units) below it; measured number inside the range.
By their numbers in this assay, from the lowest: compound 2; then compound 3; then compound 1.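

In this assay, replacing 2,6-dimethylpyridin-4-yl with 3-cyano-5-methylphenyl gives an 8.3-fold higher number from compound 2 to compound 3 (0.92 log units; beyond the scatter), so a low number at this aromatic carbon does not carry over to every group with a six-membered aromatic ring, even with the same count of hydrogen-bond acceptors. The other new comparison, a 2.3-fold lower number from compound 1 to compound 3 (0.36 log units; beyond the scatter), places 3-cyano-5-methylphenyl between the two earlier groups, giving three distinct levels at this position rather than two. Nothing shown here gives a reason for this order.

Each change replaces a whole group, so the compounds leave open which part of 2,6-dimethylpyridin-4-yl goes with its lower number. Going by these compounds, it also remains open how a plain phenyl group, or an amine in place of the nitrile, would read at this carbon.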